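Halogen Shift on the Chalcone Aryl Ring

A few compounds are considered here, and "the series" means these few. Any claim that something is new, unique, unknown or untested is made for them only; others in the source may bear on it.

Compound 1 `O=C(COc1ccc(C(=O)/C=C/c2ccccc2Cl)cc1)N[C@H]1CCOC1=O` — in a functional assay on MCF7 cells (Homo sapiens) for antiproliferative activity, read by MTT assay, with a stated time of 72 h (on this read-out lower numbers stand for stronger inhibition and higher numbers for weaker inhibition), compound 1 gives 17400 nM.
Compound 2 `CC(C)c1ccc(NCC(=O)N[C@H]2CCOC2=O)cc1` — compound 2 reaches only the assay limit of > 64000 nM in this assay.
Compound 3 `O=C(CNc1ccccc1F)N[C@H]1CCOC1=O` — compound 3 likewise reaches only the assay limit of > 64000 nM in this assay.

Among the three measured compounds, compound 1 is the only one with a number in this assay. Compound 2 and compound 3 both stand at the limit of > 64000 nM in this assay, at which 2 of the 3 values shown sit. Compound 1 thus carries the whole of the measured information, and the two limits say nothing about the size of any step from it.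

Compound 4 `O=C(COc1ccc(C(=O)/C=C/c2cccc(Br)c2)cc1)N[C@H]1CCOC1=O` is the next compound to be measured. It differs from compound 1 in a single place: 3-bromophenyl in place of 2-chlorophenyl on a double-bonded chain carbon bound to a double-bonded chain carbon. Going by the values given here, no step between two measured compounds with a comparable change is available, so the size of this step cannot be read off from the data. In the absence of such a step, no change beyond the usual scatter is expected from compound 1 to compound 4, and the estimate for the step is a 1.2-fold lower number from compound 1 to compound 4 (0.06 log units; within the scatter). Compound 4 is expected to give about 15000 nM in this assay, with a range from 5000 nM to 50000 nM.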

Compound 4, half-maximal inhibitory concentration: 28300 nM
Beside the measured number, compound 4's estimate is 1.9-fold (0.28 log units) below it, within the range that was stated.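

In this assay, going by these compounds alone, the first step that can be read at this place, on a double-bonded chain carbon bound to a double-bonded chain carbon, is a 1.6-fold higher number from compound 1 to compound 4 (0.21 log units; within the scatter). The core of compound 1 therefore tolerates this exchange of 2-chlorophenyl for 3-bromophenyl without a change beyond the scatter, although the halogen and its number in the group name differ together, and this single step cannot separate the two. Nothing measured here gives a cause for this step.

Steps to compound 2 and compound 3 cannot be read, since each of these compounds stands at a limit of the assay and not at a number. Still open, on these data alone, is whether an unsubstituted phenyl, a pyridine ring, or an aryl ring carrying an amine or a carboxylic acid at this place would also stay within the scatter of compound 1.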